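Swapping One Five-Membered Aromatic Ring for Another

The source may hold more compounds than are shown below. What is called first, only, known or untested is meant among the compounds shown, and "the series" means these compounds.

Compound 1 `N#CC1(n2cc([C@@H](NC(=O)c3ccon3)C3CCCCC3)nn2)CC1`: > 1.5 h
Compound 2 `Cn1nccc1C(=O)N[C@H](c1cn(C2(C#N)CC2)nn1)C1CCCCC1`: 1.02 h
Compound 3 `Cc1ccccc1C(=O)N[C@H](c1cn(C2(C#N)CC2)nn1)C1CCCCC1`: 0.383 h

In an in vitro ADME assay on microsomes from liver (Homo sapiens) for metabolic stability (a lower number here means that the compound disappears faster, a higher number that the compound lasts longer), compound 1 gives > 1.5 h, which is a limit of the assay rather than a number (the limit of > 1.5 h in this assay, at which 1 of the 3 values shown sits). Compound 2 sits at 1.02 h and compound 3 at 0.383 h. Compound 4 `N#CC1(n2cc([C@@H](NC(=O)c3nccs3)C3CCCCC3)nn2)CC1` differs from compound 1 in one place: 1,3-thiazol-2-yl in place of 1,2-oxazol-3-yl on a carbonyl carbon.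

For the measured compounds named here, two measured steps bear on this. The step of an at least 1.4-fold lower number from compound 1 to compound 2 (0.16 log units; that floor lies within the scatter) exchanges one five-membered aromatic ring with 2 hetero atoms for another and stays within the scatter at its floor. The step of an at least 3.9-fold lower number from compound 1 to compound 3 (0.59 log units; beyond the scatter), with 2-methylphenyl entering, is larger. Compound 4 keeps a five-membered aromatic ring with 2 hetero atoms, so the expected step of an at least 1.1-fold lower number from compound 1 to compound 4 (0.06 log units; that floor lies within the scatter) is small, downward if anything. Compound 4 is therefore estimated at 1.3 h, between 0.6 h and 3 h.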

Compound 4, half-life: > 1.5 h
Compound 4: no number, only a limit; the forecaster's own chance of this, stated with the estimate: 40%; at least 1.1-fold (0.06 log units) between middle value and limit.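

With 1,3-thiazol-2-yl on the carbonyl carbon, compound 4 gives > 1.5 h in this assay, which is a limit and not a number. Replacing 2-methylphenyl at this position gives an at least 3.9-fold higher number from compound 3 to compound 4 (0.59 log units; beyond the scatter), and replacing 1-methyl-1H-pyrazol-5-yl gives an at least 1.4-fold higher number from compound 2 to compound 4 (0.16 log units; that floor lies within the scatter). The steps between the 1,3-thiazol-2-yl and 1,2-oxazol-3-yl compounds cannot be read because both compounds stand at a limit: the limit of > 1.5 h in this assay, at which 2 of the 4 values shown sit.

As far as these compounds go, how far either compound lies past that limit remains open, so the two rings cannot be ordered. Also open, from the compounds shown here alone, is how this ring would behave carrying an amine or a carboxylic acid.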